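Dichlorophenyl acylguanidines: shifting the chlorine pattern

The source may report more compounds than this note shows. Statements on the series, on what has been measured and on what is new or still open speak of the compounds shown alone.

Among the measured compounds shown here, compound 2 `N=C(NCCCCc1ccccc1)NC(=O)c1cccc(Cl)c1Cl` gives 1480 nM in an assay on CHO cells for inhibition of sodium channel protein type 2 subunit alpha (Homo sapiens) (on this read-out higher numbers stand for weaker inhibition and lower numbers for stronger inhibition), and holds the lower of the two numbers so far; compound 1 `Cc1ccc(C(=O)NC(=N)NCCCc2ccccc2)cc1` gives 6030 nM in this assay, a gap beyond the scatter. Compound 3 `N=C(NCCCCc1ccccc1)NC(=O)c1ccc(Cl)c(Cl)c1` carries 3,4-dichlorophenyl in place of 2,3-dichlorophenyl on a carbonyl carbon. For the measured compounds named here, no single-point step between measured compounds exists to guide the size of this move, so the expected step from compound 2 to compound 3 is a 1.2-fold higher number from compound 2 to compound 3 (0.09 log units; within the scatter), kept within the scatter in either direction. Compound 3 is therefore estimated at 1800 nM in this assay, with a range from 600 nM to 5500 nM.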

Compound 3, half-maximal inhibitory concentration: 7110 nM
Estimate against measurement, compound 3: 4.0-fold (0.60 log units) below, outside the stated range (above it).
By their numbers in this assay, from the lowest: compound 2; then compounds 1 and 3 (each within the scatter of the next).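

In this assay, moving the chlorines with no change in atoms gives a 4.8-fold higher number from compound 2 to compound 3 (0.68 log units; beyond the scatter), so the number at this carbonyl carbon depends on the chlorine pattern and not only on the presence of two chlorines. Of this pair, 2,3-dichlorophenyl holds the lower number. Nothing available explains the shift.

On these data alone, whether 2,4-dichlorophenyl or 3,5-dichlorophenyl would stay nearer compound 2 or compound 3 remains open. So does the outcome with a single chlorine or a methoxy group on the phenyl ring.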